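Removing one chloro from a dichlorobenzyl amide

A few compounds are considered here, and "the series" means these few. Any claim that something is new, unique, unknown or untested is made for them only; others in the source may bear on it.

Measured so far:
compound 1, `CC(C)[C@H](N)c1cccc(F)c1N1CCN(C(=O)[C@H](C)Cc2ccc(Cl)cc2Cl)CC1`, 27 nM
compound 2, `CC(C)[C@H](NC(=O)CCN(C)C)c1ccccc1N1CCN(C(=O)[C@H](C)Cc2ccc(Cl)cc2)CC1`, 24 nM

In an assay on HEK293 cells for displacement of a labelled ligand from Melanocortin receptor 4 (Homo sapiens) (a lower number here means a stronger inhibitor, a higher number a weaker inhibitor), compound 1 gives 27 nM, and compound 2 gives 24 nM in this assay; the two numbers lie within the usual scatter of each other, so neither can be called the stronger binder. Compound 3, `CC(C)[C@H](N)c1cccc(F)c1N1CCN(C(=O)[C@H](C)Cc2ccc(Cl)cc2)CC1`, has not yet been measured. It differs from compound 1 by hydrogen in place of chloro on an aromatic carbon, turning the 2,4-dichlorobenzyl group into a 4-chlorobenzyl group. Going by the values given here, no measured pair shows this change alone. Compound 2 carries the same 4-chlorobenzyl group and still gives 24 nM, so a small step is expected, if any, a 1.5-fold higher number from compound 1 to compound 3 (0.17 log units; within the scatter). Compound 3 is estimated at 40 nM, in the range 15 nM to 120 nM.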

Compound 3, inhibition constant: 83 nM
Beside the measured number, compound 3's estimate is 2.1-fold (0.32 log units) below it; measured number inside the range.
By their numbers in this assay, from the lowest: compounds 2 and 1 (each within the scatter of the next); then compound 3.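

In this assay, putting hydrogen in place of the chloro ortho to a large group gives a 3.1-fold higher number from compound 1 to compound 3 (0.49 log units; beyond the scatter), a modest step but beyond the scatter. Going by these compounds alone, this is the first pair differing in one place only, and it shows that on this core the 2,4-dichlorobenzyl group binds more tightly than the 4-chlorobenzyl group. Nothing measured here explains why this chloro matters.

As far as these compounds go, whether a methyl or methoxy group on this same carbon would do as well as chloro stays open. So does whether the step would be the same size with the longer amide chain of compound 2 in place.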